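Ethyl Added to the Core: Compound 1 to Compound 4

The compounds below may be only part of what the source reports. "The series", "measured", "known", "first", "only" and "open" are said of these compounds alone.

Compound 1 `CC1CCC(=NNc2ccccc2)c2ncc(C(=O)O)c(=O)n21`: 1.2 umol/kg
Compound 2 `Cc1cc(C)cc(NN=C2CCC(C)n3c2ncc(C(=O)O)c3=O)c1`: > 320 umol/kg
Compound 3 `CC1CCC(=NNc2cc(Cl)cc(Cl)c2)c2ncc(C(=O)O)c(=O)n21`: > 100 umol/kg

Among the measured compounds shown here, in a functional assay on the whole organism with Rattus norvegicus as the target (on this read-out higher numbers stand for an effect only at larger amounts of compound and lower numbers for an effect already at smaller amounts), compound 1 gives 1.2 umol/kg, the only true number among the three values. For compound 2 the value > 320 umol/kg is a limit of the assay, not a number. For compound 3 the value > 100 umol/kg is likewise a limit. The measured steps of an at least 260-fold higher number from compound 1 to compound 2 (2.42 log units; beyond the scatter) and an at least 83-fold higher number from compound 1 to compound 3 (1.92 log units; beyond the scatter) both alter the aryl group on the amine nitrogen and leave the core untouched. Compound 4 `CCc1nc2n(c(=O)c1C(=O)O)C(C)CCC2=NNc1ccccc1` differs from compound 1 elsewhere: ethyl in place of hydrogen on an aromatic carbon. For the measured compounds named here, no measured step touches that position, so those steps give no direct guide. The step of a 2.5-fold higher number from compound 1 to compound 4 (0.40 log units; beyond the scatter) is therefore estimated to be modest, in either direction. For compound 4 the expected value is 3 umol/kg, with a range from 0.6 umol/kg to 20 umol/kg.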

Compound 4, dose for 50% inhibition: > 320 umol/kg
Compound 4: a limit, no number; the forecaster's own chance of this, stated with the estimate: 15%; middle value at least 100-fold (2.02 log units) from the limit.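

Placing ethyl on an aromatic carbon, ortho to the carboxy group, changes the core rather than the aryl group on the amine nitrogen, and it gives an at least 260-fold higher number from compound 1 to compound 4 (2.42 log units; beyond the scatter). This position on the core therefore matters as much as that aryl group: even this small chain takes compound 4 out of the measurable range. The value of compound 4 is a limit and not a number: the limit of > 320 umol/kg in this assay, at which 2 of the 4 values shown sit.

As far as these compounds go, whether methyl, a hydroxyl or an amine at this position would keep the effect of compound 1 stays open. From the compounds shown here alone, the true size of the step also stays open.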